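Regioisomeric oxolane swap on an amidated melanocortin receptor ligand

This account rests on a few compounds, and the source may have more. Where it says the series, first, only, none or still open, it means among the compounds named here.

Compound 1 `CC(C)C[C@H](N)c1cc(C(F)(F)F)ccc1N1CCN(C(=O)C2COCC2c2ccc(Cl)cc2)CC1` gives 280 nM in an assay on HEK293 cells for displacement of a labelled ligand from Melanocortin receptor 4 (Homo sapiens); on this read-out higher numbers stand for weaker inhibition and lower numbers for stronger inhibition. Compound 2 `CC(C)C[C@H](N)c1cc(C(F)(F)F)ccc1N1CCN(C(=O)[C@H]2CCO[C@@H]2c2ccc(Cl)cc2)CC1` differs from it by 2-(4-chlorophenyl)oxolan-3-yl in place of 4-(4-chlorophenyl)oxolan-3-yl on a carbonyl carbon; on this change a 1.2-fold higher number from compound 1 to compound 2 (0.07 log units; within the scatter), and compound 2 gives 330 nM. Compound 3 `CC(C)C[C@H](NC(=O)CCN(C)C)c1cc(C(F)(F)F)ccc1N1CCN(C(=O)C2COCC2c2ccc(Cl)cc2)CC1` differs from compound 1 by (2-(dimethylamino)ethyl)carbonyl in place of hydrogen on an amine nitrogen; here a 3.9-fold lower number from compound 1 to compound 3 (0.60 log units; beyond the scatter), and compound 3 gives 71 nM in this assay, the lowest of the three measured values. Compound 4 `CC(C)C[C@H](NC(=O)CCN(C)C)c1cc(C(F)(F)F)ccc1N1CCN(C(=O)[C@H]2CCO[C@@H]2c2ccc(Cl)cc2)CC1` has not yet been measured. It differs from compound 3 by 2-(4-chlorophenyl)oxolan-3-yl in place of 4-(4-chlorophenyl)oxolan-3-yl on a carbonyl carbon, the same change that turned compound 1 into compound 2, made in both cases on a carbonyl carbon whose other neighbours are an amide-type nitrogen in a ring. Since that earlier change produced a 1.2-fold higher number from compound 1 to compound 2 (0.07 log units; within the scatter), the step from compound 3 to compound 4 in this assay is expected to be of similar size, a 1.2-fold higher number from compound 3 to compound 4 (0.08 log units; within the scatter). Compound 4 is therefore estimated at 85 nM, expected to lie between 40 nM and 180 nM.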

Compound 4, inhibition constant: 200 nM
For compound 4 the middle estimate is 2.4-fold (0.37 log units) below the measured one; the measured number lies above the stated range.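

In this assay, the swap to 2-(4-chlorophenyl)oxolan-3-yl on the amidated core gave a 2.8-fold higher number from compound 3 to compound 4 (0.45 log units; beyond the scatter), and this step does not differ from the one on the free amine core beyond what two such steps can scatter: the same change on two cores in this assay, a 1.2-fold higher number (0.07 log units; within the scatter) from compound 1 to compound 2 and a 2.8-fold higher number (0.45 log units; beyond the scatter) from compound 3 to compound 4, 2.4-fold (0.38 log units) apart, within the scatter of two such steps. Adding (2-(dimethylamino)ethyl)carbonyl to the core bearing that oxolane gave a 1.7-fold lower number from compound 2 to compound 4 (0.22 log units; within the scatter), which also agrees with its earlier counterpart within that scatter: the same change on two cores in this assay, a 3.9-fold lower number (0.60 log units; beyond the scatter) from compound 1 to compound 3 and a 1.7-fold lower number (0.22 log units; within the scatter) from compound 2 to compound 4, 2.4-fold (0.38 log units) apart, within the scatter of two such steps. Within the data shown here, the four compounds are thus compatible with each change carrying from one core to the other, but with only one pair of steps per change they neither establish this nor rule out a dependence on the core.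

As far as these compounds go, it remains open whether the same holds with an acetyl group or a longer aminoalkyl chain on the amine nitrogen. The compounds also leave open how the chlorine of the 4-chlorophenyl group, if replaced by fluorine or a methyl group, would affect either step.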